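The source may hold more compounds than are shown below. What is called first, only, known or untested is meant among the compounds shown, and "the series" means these compounds.

Working notes on the series. Three members are measured so far: compound 1 `O=C(CSc1nnc(-c2ccncc2)o1)N/N=C/c1ccc(Br)cc1`, compound 2 `O=C(CSc1nnc(-c2ccncc2)o1)N/N=C/c1ccc([N+](=O)[O-])cc1` and compound 3 `O=C(CSc1nnc(-c2ccncc2)o1)N/N=C/c1cc(Cl)ccc1O`. In a functional assay on SW 1116 cells (Homo sapiens) for cytotoxicity, read by MTT assay, with a stated time of 48 h (on this read-out higher numbers stand for weaker inhibition and lower numbers for stronger inhibition), compound 1 gives 21300 nM. Compound 2 gives 25800 nM. Compound 3 gives 5240 nM. The step of a 1.2-fold higher number from compound 1 to compound 2 (0.08 log units; within the scatter) is flat. The steps of a 4.1-fold lower number from compound 1 to compound 3 (0.61 log units; beyond the scatter) and a 4.9-fold lower number from compound 2 to compound 3 (0.69 log units; beyond the scatter) both run downward, so compound 3 stands lowest of the three numbers, separated from each of the others by more than the scatter.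

Compound 4 `O=C(CSc1nnc(-c2ccncc2)o1)N/N=C/c1cc(Cl)cc(Cl)c1O` is the next member. The change is chloro in place of hydrogen on an aromatic carbon. Among the compounds with values here, no measured step alters the 5-chloro-2-hydroxyphenyl itself. Within the data shown here, the two steps that reach compound 3 exchange the whole aryl group, and the only step that exchanges a single substituent on an otherwise fixed aryl, a 1.2-fold higher number from compound 1 to compound 2 (0.08 log units; within the scatter), stays within the scatter. One added chloro is therefore expected to move the number in this assay only a little, with neither direction well supported by the data. The expected step is a 1.2-fold lower number from compound 3 to compound 4 (0.07 log units; within the scatter). Compound 4 is estimated at 4500 nM, with a range from 1800 nM to 12000 nM.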

Compound 4, half-maximal inhibitory concentration: 5030 nM
Estimate against measurement, compound 4: 1.1-fold (0.05 log units) below; low and high end bracket the measured number.
By their numbers in this assay, from the lowest: compounds 4 and 3 (each within the scatter of the next); then compounds 1 and 2 (each within the scatter of the next).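

In this assay, the change to the 5-chloro-2-hydroxyphenyl itself, chloro in place of hydrogen on the aromatic carbon ortho to the hydroxy group, gives a 1.0-fold lower number from compound 3 to compound 4 (0.02 log units; within the scatter), so this position takes a second chloro with no change beyond the scatter. The resulting 3,5-dichloro-2-hydroxyphenyl keeps the separation from the other two aryl groups, with a 5.1-fold lower number from compound 2 to compound 4 (0.71 log units; beyond the scatter) and a 4.2-fold lower number from compound 1 to compound 4 (0.63 log units; beyond the scatter), so among the four compounds the two carrying a hydroxy group and chloro on the aryl both stand apart from compounds 1 and 2, and no compound shown goes against this. No evidence at hand bears on this result.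

The compounds shown leave open whether the flat step is particular to chloro or whether a methoxy group or an amine on the same carbon would also leave the number in place. They also leave open how much of the gap to compounds 1 and 2 belongs to the hydroxy group and how much to the 5-chloro, as each step to those two compounds exchanges the whole aryl group.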